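The source may hold more compounds than are shown below. What is called first, only, known or untested is meant among the compounds shown, and "the series" means these compounds.

Measured in a functional assay on KB cells (Homo sapiens) for antiproliferative activity, read by colorimetric assay and MTT assay; on this read-out higher numbers stand for weaker inhibition and lower numbers for stronger inhibition:
- compound 1 `O=[N+]([O-])c1ccc(S(=O)(=O)Nc2cccc3cc(Cl)[nH]c23)cc1`: 18 ug/mL
- compound 2 `Cc1ccc(S(=O)(=O)Nc2cccc3cc(Cl)[nH]c23)cc1`: 0.11 ug/mL
- compound 3 `Nc1ccc(S(=O)(=O)Nc2cccc3cc[nH]c23)cc1`: 36 ug/mL

In this assay, compound 3 lies within the scatter of compound 1 and far above compound 2. Compound 4 `Nc1ccc(S(=O)(=O)Nc2cccc3cc(Cl)[nH]c23)cc1` adds one change to compound 3: chloro in place of hydrogen on an aromatic carbon. Going by the values given here, no measured step tests this swap directly. Among the compounds with values here, the only measured step is a 160-fold lower number from compound 1 to compound 2 (2.21 log units; beyond the scatter), a large one, made at another place between two compounds that both carry the chloro. Compound 1 therefore shows that the chloro does not by itself ensure a low number. A moderate to large step towards a lower number is still expected, with wide uncertainty. The estimated step is a 12-fold lower number from compound 3 to compound 4 (1.08 log units; beyond the scatter). For compound 4 the expected value is 3 ug/mL, with an estimated range of 0.3 ug/mL to 30 ug/mL.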

Compound 4, half-maximal inhibitory concentration: 1.4 ug/mL
Beside the measured number, compound 4's estimate is 2.1-fold (0.33 log units) above it, within the range that was stated.
By their numbers in this assay, from the lowest: compound 2; then compound 4; then compounds 1 and 3 (each within the scatter of the next).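

In this assay, going by these compounds alone, chloro in place of hydrogen next to the ring nitrogen gives a 26-fold lower number from compound 3 to compound 4 (1.41 log units; beyond the scatter), the first direct reading of this change, made with the amino group kept. With the chloro kept, amino in place of methyl gives a 13-fold higher number from compound 2 to compound 4 (1.10 log units; beyond the scatter), and amino in place of nitro gives a 13-fold lower number from compound 1 to compound 4 (1.11 log units; beyond the scatter), which places compound 4 in the middle of the three chloro compounds. No evidence at hand accounts for the size of these steps.

Open, as far as these compounds go, is whether the chloro step holds with methyl or nitro in place of the amino group. Also open, from the compounds shown here alone, is how bromo, fluoro or methyl would compare with chloro on the same carbon.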